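A few compounds are considered here, and "the series" means these few. Any claim that something is new, unique, unknown or untested is made for them only; others in the source may bear on it.

In an ADME assay on S9 fraction from liver (Homo sapiens) for metabolic stability, read by LC-MS, using NADPH, with a stated time of 90 min, tested at 5 uM (a lower number here means that less of the compound is left, a higher number that more of the compound is left), compound 1 (`Cn1c(Sc2c(F)cc(C(=O)NO)cc2F)nnc1-c1cccs1`) gives 83%. Compound 3 (`O=C(NO)c1ccc(Cn2nnc(-c3ncccn3)n2)cc1`) gives 83%, and compound 2 (`Cn1c(Sc2c(F)cc(C(=O)NO)cc2F)nnc1-c1cccc(CN2CCCCCC2)c1`) gives 78%. These three numbers lie within the usual scatter of one another, so compound 1 stands level with both.

Compound 4 (`Cc1cc(-c2nnc(Sc3c(F)cc(C(=O)NO)cc3F)n2C)nn1C`) keeps the core of compound 1 and differs from it in one group: 1,5-dimethyl-1H-pyrazol-3-yl in place of thiophen-2-yl on an aromatic carbon. The change places 1,5-dimethyl-1H-pyrazol-3-yl in place of thiophen-2-yl on an aromatic carbon of a five-membered aromatic ring with 3 nitrogen. Going by the values given here, no pair of measured compounds differs in only one place, so no measured step speaks directly to this change.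

The nearest guide is compound 2, which carries a different group at that same place and gives 78%, still within the scatter of compound 1. No step beyond the scatter is therefore expected in this assay. The estimated change is a number 3 percentage points lower from compound 1 to compound 4 (within the scatter). For compound 4 the estimated value is 80%, with an expected range of 68% to 90%.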

Compound 4, percent of the compound remaining: 76%
For compound 4 the middle estimate is 4 percentage points above the measured one; measured number inside the range.
By their numbers in this assay, from the lowest: compounds 4, 2, 1 and 3 (each within the scatter of the next).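

Going by these compounds alone, compound 4 gives the first reading of a change at this aromatic carbon with the rest of the molecule held constant: in this assay, placing 1,5-dimethyl-1H-pyrazol-3-yl in place of thiophen-2-yl gives a number 7 percentage points lower from compound 1 to compound 4 (within the scatter). The step therefore shows that, at this place, a five-membered aromatic ring with 2 hetero atoms and a five-membered aromatic ring with 1 hetero atom cannot be told apart in this read-out, even though the entering group is the larger by heavy atoms. No measurement shown here offers an explanation for the size of this step. On these data alone, whether a primary amine or a carboxylic acid at this place would give a step beyond the scatter remains open. So does the outcome of replacing the methyl group on the neighbouring ring atom with an ethyl group.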